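Fluoro for Methoxy: A Single Change in a Weak Inhibitor

A few compounds are considered here, and "the series" means these few. Any claim that something is new, unique, unknown or untested is made for them only; others in the source may bear on it.

Compound 1, `CCOC(=O)[C@H](CCC(=O)O)NC(=O)c1ccc(Oc2nc3cc(N)cc(N)c3nc2-c2ccccc2)cc1`: 26900 nM
Compound 2, `COc1ccc(Sc2nc3cc(N)cc(N)c3nc2-c2ccccc2)cc1`: 43700 nM

Of the compounds shown here, two have been tested in a functional assay on UACC-257 cells (Homo sapiens) for inhibition, read by sulforhodamine B assay, with a stated time of 48 h; a higher number here means a weaker inhibitor of growth, a lower number a stronger inhibitor of growth. Compound 1 gives 26900 nM, and compound 2 gives 43700 nM. These two numbers lie within the usual scatter of each other, so neither compound can be called the stronger or the weaker inhibitor. Compound 1 and compound 2 differ in many places at once, so no single step can be read from them.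

Compound 3, `Nc1cc(N)c2nc(-c3ccccc3)c(Sc3ccc(F)cc3)nc2c1`, has not yet been measured in this assay. It differs from compound 2 in one place only: fluoro in place of methoxy on an aromatic carbon. For the measured compounds named here, no measured pair shares this change, so the expected step in this assay is none beyond the scatter, and the number for compound 3 is expected to stay close to that of compound 2. The expected step is a 1.1-fold lower number from compound 2 to compound 3 (0.04 log units; within the scatter). For compound 3 the estimate is 40000 nM, with a range from 15000 nM to 110000 nM.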

Compound 3, concentration for 50% growth inhibition: 16600 nM
Estimate against measurement, compound 3: 2.4-fold (0.38 log units) above; the measured number falls inside the stated range.
By their numbers in this assay, from the lowest: compounds 3, 1 and 2 (each within the scatter of the next, the first and the last beyond it).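

For the compounds shown here, replacing methoxy with fluoro gives a 2.6-fold lower number from compound 2 to compound 3 (0.42 log units; beyond the scatter) in this assay and is the first single change that can be read. It shows that this place, on an aromatic carbon para to a large group, is not silent: swapping one small group for another moves the number, though only by a modest step. No measurement here explains why the number moves. The compounds shown leave open how other groups at this place, such as chloro, hydroxyl or an amine, would compare with fluoro and methoxy. They also leave open whether the same swap would give a similar step in a compound joined through oxygen rather than sulfur, as compound 1 is.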